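Replacing the pyrazole amide in a urotensin receptor antagonist

The source may hold more compounds than are shown below. What is called first, only, known or untested is meant among the compounds shown, and "the series" means these compounds.

Compound 2 `CCN1CCN(c2cccc3c2CN([C@H](CCCNC(=O)c2c(C)n[nH]c2C)c2ccc(OC)c(OC)c2)C3=O)CC1` has the lowest of the two numbers recorded so far: in a functional assay on CHO-K1 cells for antagonist activity at Urotensin-2 receptor (Rattus norvegicus), read by FLIPR and calcium flux, with a stated time of 1 h (on this read-out higher numbers stand for weaker inhibition and lower numbers for stronger inhibition), compound 2 gives 16 nM, while compound 1 `CCN1CCN(c2cccc3c2C(=O)N([C@H](CCCNS(=O)(=O)c2cn(C)c(C)n2)c2ccc(OC)c(OC)c2)C3=O)CC1` gives 140 nM. Compound 3 `CCN1CCN(c2cccc3c2CN([C@H](CCCNc2cncc(OC)n2)c2ccc(OC)c(OC)c2)C3=O)CC1` is not yet measured; it differs from compound 2 by one change, (6-methoxypyrazin-2-yl in place of (3,5-dimethyl-1H-pyrazol-4-yl)carbonyl on an amine nitrogen). Going by the values given here, no directly comparable step is available, so the expectation rests on compound 2 alone. A modest loss of potency, beyond the scatter, is expected, as a 2.8-fold higher number from compound 2 to compound 3 (0.45 log units; beyond the scatter). Compound 3 is accordingly estimated at 45 nM, with a range from 12 nM to 180 nM.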

Compound 3, half-maximal inhibitory concentration: 4 nM
Beside the measured number, compound 3's estimate is 11-fold (1.05 log units) above it; measured number below the stated range.
By their numbers in this assay, from the lowest: compound 3; then compound 2; then compound 1.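

On the amine nitrogen, whose other neighbour is a saturated chain carbon, the (3,5-dimethyl-1H-pyrazol-4-yl)carbonyl group proves dispensable in this assay: 6-methoxypyrazin-2-yl takes its place and gives a 4.0-fold lower number from compound 2 to compound 3 (0.60 log units; beyond the scatter) on this read-out. Potency at this position therefore does not depend on a carbonyl on this nitrogen or on a hydrogen-bond donor in the group it carries. Nothing shown here bears on why the number falls.

The compounds shown leave open whether the methoxy group contributes to this result, and whether an unsubstituted pyrazine, a pyrimidine or a pyridine on this nitrogen would read the same.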